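A few compounds are considered here, and "the series" means these few. Any claim that something is new, unique, unknown or untested is made for them only; others in the source may bear on it.

Compound 1 `Cc1ccc(NC(=O)Nc2cccc(CNc3nccnc3Cl)c2)cc1C` gives 9870 nM in a functional assay on MGC-803 cells (Homo sapiens) for antiproliferative activity, read by MTT assay, with a stated time of 48 h; on this read-out lower numbers stand for stronger inhibition and higher numbers for weaker inhibition. Compound 2 `O=C(Nc1cccc(CNc2nccnc2Cl)c1)Nc1cccc(C(F)(F)F)c1` gives 7290 nM and compound 3 `COc1ccccc1NC(=O)Nc1cccc(CNc2nccnc2Cl)c1` gives 12200 nM in this assay; all three numbers sit within the scatter of one another, so no ranking among them is secure. Among the measured compounds shown here, the single one-change step so far, a 1.2-fold higher number from compound 1 to compound 3 (0.09 log units; within the scatter), is itself within the scatter. Compound 4 `O=C(Nc1cccc(Cl)c1)Nc1cccc(CNc2nccnc2Cl)c1` differs from compound 1 by 3-chlorophenyl in place of 3,4-dimethylphenyl on an amide-type nitrogen. For the measured compounds named here, no measured step matches this exact change; the nearest reference is compound 2, whose value set against that of compound 1 again shows no gap beyond the scatter. For compound 4 a step of a 1.2-fold lower number from compound 1 to compound 4 (0.06 log units; within the scatter) is therefore expected, not beyond the scatter. Compound 4 is estimated at 8500 nM, with a range from 3500 nM to 20000 nM.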

Compound 4, half-maximal inhibitory concentration: 5330 nM
Beside the measured number, compound 4's estimate is 1.6-fold (0.20 log units) above it, and the stated range covers the measured number.
By their numbers in this assay, from the lowest: compounds 4, 2, 1 and 3 (each within the scatter of the next, the first and the last beyond it).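

Among the compounds shown here, at this place on an amide-type nitrogen, 3-chlorophenyl gives the first step beyond the scatter in this assay, a modest one against 2-methoxyphenyl (a 2.3-fold lower number from compound 3 to compound 4 (0.36 log units; beyond the scatter)). Against 3,4-dimethylphenyl (a 1.9-fold lower number from compound 1 to compound 4 (0.27 log units; within the scatter)) and with chloro in place of trifluoromethyl on an aromatic carbon (a 1.4-fold lower number from compound 2 to compound 4 (0.14 log units; within the scatter)), the steps stay within the scatter. Compound 4 thus separates only from compound 3, and no secure ranking extends to compound 1 or compound 2.

No available evidence bears on this result. As far as these compounds go, whether an amine or a carboxylic acid on this phenyl ring would shift the number further remains open.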